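A few compounds are considered here, and "the series" means these few. Any claim that something is new, unique, unknown or untested is made for them only; others in the source may bear on it.

- compound 1 (`Cc1nn(-c2ccccc2)c(Oc2ccc(-c3nc4cc([N+](=O)[O-])ccc4[nH]3)cc2)c1/C=N/Nc1ccccc1`): "not determined" (no result reported)
- compound 2 (`Cc1nn(-c2ccccc2)c(Oc2ccc(-c3nc4cc([N+](=O)[O-])ccc4[nH]3)cc2)c1/C=N/NC(N)=O`): 60 nM
- compound 3 (`Cc1nn(-c2ccccc2)c(Oc2ccc(-c3nc4cc([N+](=O)[O-])ccc4[nH]3)cc2)c1/C=N/NC(N)=S`): "not determined" (no result reported)

In a functional assay on MCF7 cells (Homo sapiens) for cytotoxicity, read by sulforhodamine B assay, with a stated time of 48 h, in the presence of a further agent that is not named here (on this read-out lower numbers stand for stronger inhibition of growth and higher numbers for weaker inhibition of growth), compound 1 stands at "not determined" (no result reported), so it offers no single number, and compound 3 is in the same position. Compound 2 alone gives a number, at 60 nM. The step to compound 4 (`Cc1nn(-c2ccccc2)c(Oc2ccc(-c3nc4cc(C(=O)O)ccc4[nH]3)cc2)c1/C=N/Nc1ccccc1`) places carboxy in place of nitro on an aromatic carbon. A moderate step towards weaker inhibition of growth in this assay is expected from this change, somewhat beyond the scatter, although it has no measured starting point in compound 1. The expectation therefore rests loosely on compound 2 at 60 nM. For compound 4 the estimated value is 250 nM, with an expected range of 40 nM to 1500 nM.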

Compound 4, concentration for 50% growth inhibition: 50 nM
Beside the measured number, compound 4's estimate is 5.0-fold (0.70 log units) above it, within the range that was stated.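

In this assay, going by these compounds alone, compound 1 stands at "not determined" (no result reported) and compound 4 at 50 nM, so no step between them can be read. The compounds shown leave open what carboxy in place of nitro does to inhibition of growth in this assay, and no evidence at hand bears on the result.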